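Notes on the step from compound 3 to compound 4

A few compounds are considered here, and "the series" means these few. Any claim that something is new, unique, unknown or untested is made for them only; others in the source may bear on it.

Measured so far in a functional assay on PC-3 cells (Homo sapiens) for cytotoxicity, read by MTT assay, with a stated time of 48 h; on this read-out lower numbers stand for stronger inhibition and higher numbers for weaker inhibition:
- compound 1 `CC1=NN(S(=O)(=O)c2ccc([N+](=O)[O-])cc2)C(c2cc(Cl)ccc2O)C1`, compound 1 gives 44200 nM
- compound 2 `O=c1oc2ccccc2cc1C1=NN(S(=O)(=O)c2ccc([N+](=O)[O-])cc2)C(c2ccccc2)C1`, compound 2 gives 46600 nM
- compound 3 `Cc1ccc(S(=O)(=O)N2N=C(c3cc4ccccc4oc3=O)CC2c2ccccc2)cc1`, compound 3 gives 48600 nM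

The three numbers sit close together: compound 3 lies within the scatter of compound 2 and of compound 1, so no order among them can be read. Among the compounds with values here, the one measured step, a 1.0-fold higher number from compound 2 to compound 3 (0.02 log units; within the scatter), is within the scatter and concerns a change on an aromatic carbon of the sulfonyl group.

Compound 4 `O=C(CNC1CCCCC1)N1N=C(c2cc3ccccc3oc2=O)CC1c1ccccc1` differs from compound 3 by ((cyclohexylamino)methyl)carbonyl in place of (4-methylphenyl)sulfonyl on an amine nitrogen in a ring. Within the data shown here, no measured step touches this position, so nothing bears directly on it. The expectation for compound 4 is therefore a step of about a 1.1-fold lower number from compound 3 to compound 4 (0.03 log units; within the scatter) in this assay, none beyond the scatter, with wide uncertainty. Compound 4 is estimated at 45000 nM, range 10000 nM to 150000 nM.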

Compound 4, half-maximal inhibitory concentration: 48500 nM
Estimate against measurement, compound 4: 1.1-fold (0.03 log units) below, within the range that was stated.
By their numbers in this assay, from the lowest: compounds 1, 2, 4 and 3 (each within the scatter of the next).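

In this assay the exchange on the amine nitrogen in a ring gives a 1.0-fold lower number from compound 3 to compound 4 (0.00 log units; within the scatter) and so separates ((cyclohexylamino)methyl)carbonyl from (4-methylphenyl)sulfonyl in no readable way. This position therefore accepts a non-aromatic ring of carbon only in place of an aromatic one, with a hydrogen-bond donor gained, and no difference can be read. No available evidence accounts for this result.

From the compounds shown here alone, whether a smaller group on this nitrogen, such as acetyl, or a carboxylic acid on a longer chain would move the number beyond the scatter remains open.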